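The source may report more compounds than this note shows. Statements on the series, on what has been measured and on what is new or still open speak of the compounds shown alone.

Compound 1 `COc1cc(-c2cc(/C=C/C(=O)c3ccc(Cl)c(Cl)c3)[nH]n2)cc(OC)c1OC` and compound 2 `COc1ccc(C(=O)/C=C/c2cc(-c3cc(OC)c(OC)c(OC)c3)n[nH]2)cc1OC` share one core and differ only in the aryl group attached to the carbonyl carbon. In a functional assay on SNB-19 cells (Homo sapiens) for cytotoxicity, read by sulforhodamine B assay, with a stated time of 48 h, tested at 0.1 uM (on this read-out higher numbers stand for a weaker effect at the one concentration tested and lower numbers for a stronger effect), compound 1 gives 92%, and in this assay compound 2 gives 93%. The step of a number 1 percentage points higher from compound 1 to compound 2 (within the scatter) shows that replacing 3,4-dichlorophenyl with 3,4-dimethoxyphenyl on the carbonyl carbon changed nothing of note. Compound 2 thus stands with the highest of the two numbers, its nearest neighbour being compound 1, which sits within the scatter of it.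

Compound 3 `COc1cc(-c2cc(/C=C/C(=O)c3ccc(F)c(F)c3)[nH]n2)cc(OC)c1OC` continues the series at the same position: 3,4-difluorophenyl in place of 3,4-dimethoxyphenyl on a carbonyl carbon. Among the measured compounds shown here, the only measured step that bears on this exchange is a number 1 percentage points higher from compound 1 to compound 2 (within the scatter), which was within the scatter. Since that step involved the same ring on the carbonyl carbon and compound 3 again carries halogens there, the expected step is a number 1 percentage points lower from compound 2 to compound 3 (within the scatter), that is, none beyond the scatter. On this basis compound 3 is estimated in this assay at 92%, with a range from 82% to 100%.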

Compound 3, a percentage reported as activity, at one concentration (the size of the read-out at that concentration, not a potency): 87%
The estimate for compound 3 lay 5 percentage points above the measured number; measured number inside the range.
By their numbers in this assay, from the lowest: compounds 3, 1 and 2 (each within the scatter of the next).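

With 3,4-difluorophenyl on the carbonyl carbon, three different aryl groups have now been compared at this position, and in this assay the exchange for 3,4-dimethoxyphenyl gives a number 6 percentage points lower from compound 2 to compound 3 (within the scatter) while the exchange for 3,4-dichlorophenyl gives a number 5 percentage points lower from compound 1 to compound 3 (within the scatter) on the same read-out. Both steps lie within the scatter, so the earlier finding for a single exchange now holds for all three pairs among compounds 1, 2 and 3, and these compounds cannot be told apart at the one concentration tested. Nothing available explains why these exchanges leave the read-out within the scatter, and no cause can be offered.

On these data alone, all three compounds carry a phenyl ring on the carbonyl carbon, so it remains open whether an amine or a carboxylic acid on that ring, or a longer chain in its place, would give a step beyond the scatter. As far as these compounds go, with a single concentration as the only read-out, it also remains open whether compounds 1, 2 and 3 would separate at other concentrations.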